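The source may hold more compounds than are shown below. What is called first, only, known or untested is meant among the compounds shown, and "the series" means these compounds.

Series notes, cytotoxicity on the shared salicylanilide scaffold.

Measured so far:
compound 1, `O=C(Nc1cc(C(F)(F)F)cc(C(F)(F)F)c1)c1cc(Br)ccc1O`, 290 nM
compound 2, `N#Cc1ccc(NC(=O)c2ccc(F)cc2O)cc1`, 1380 nM
compound 3, `N#Cc1ccc(NC(=O)c2ccc3ccccc3c2O)cc1`, 3410 nM

All three values come from a functional assay on HL-60 cells (Homo sapiens) for cytotoxicity, read by luminescence and CellTiter-Glo, with a stated time of 3 days; a lower number here means a stronger inhibitor, a higher number a weaker inhibitor. Compound 1 holds the lowest number of the three; its gap to compound 2 and its gap to compound 3 both lie beyond the scatter, so compound 1 is the strongest inhibitor of this small set. Among the compounds with values here, compound 2 and compound 3 share the nitrile-bearing anilide half and differ in the acid half; no step between them is computed here, so only the two values themselves are noted.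

Compound 4, `O=C(Nc1cc(C(F)(F)F)cc(C(F)(F)F)c1)c1ccc(Br)cc1O`, is not yet measured in this assay. It keeps every atom of compound 1 and differs only in how the acid half is joined:

4-bromo-2-hydroxyphenyl in place of 5-bromo-2-hydroxyphenyl on a carbonyl carbon

Within the data shown here, no measured pair in the set isolates a change of this kind, so the expected step rests on the structural similarity alone. The move of bromine on the same ring is expected to cost little; the step from compound 1 to compound 4 is estimated as a 1.4-fold higher number from compound 1 to compound 4 (0.16 log units; within the scatter), a slight loss at most, quite possibly none beyond the scatter. For compound 4 the estimate in this assay is 420 nM, with a range from 150 nM to 1200 nM.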

Compound 4, half-maximal inhibitory concentration: 270 nM
Beside the measured number, compound 4's estimate is 1.6-fold (0.19 log units) above it; the measured number falls inside the stated range.
By their numbers in this assay, from the lowest: compounds 4 and 1 (each within the scatter of the next); then compound 2; then compound 3.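

In this assay, 4-bromo-2-hydroxyphenyl in place of 5-bromo-2-hydroxyphenyl on a carbonyl carbon gives a 1.1-fold lower number from compound 1 to compound 4 (0.03 log units; within the scatter), so this change of bromine placement leaves no readable difference in the cytotoxicity read-out. Within the data shown here, this is the first pair that differs in one place, and it shows that, with the anilide half carrying two trifluoromethyl groups held fixed, the two bromine placements cannot be told apart in this cell assay. No measurement shown here bears on why the two placements read alike.

From the compounds shown here alone, the pair covers only bromine in these two placements, so it remains open whether the same flat reading would hold for a chlorine, a methoxy group, an amine or a carboxylic acid on the acid half, or whether the hydroxyl itself could give way to a methoxy group. Going by these compounds, it also remains open whether a move of bromine on the acid half would read the same with the nitrile-bearing anilide half shared by compound 2 and compound 3.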